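The source may hold more compounds than are shown below. What is called first, only, known or untested is meant among the compounds shown, and "the series" means these compounds.

Measured so far in an ADME assay on K562 cells (Homo sapiens) for cytotoxicity, with a stated time of 72 h; a higher number here means a weaker inhibitor, a lower number a stronger inhibitor:
Compound 1 `Oc1cccc(CNc2ncnc3c2ncn3C2CCCCO2)c1` gives 81000 nM (a number)
Compound 2 `COc1ccc(CNc2ncnc3c2ncn3C2CCCCO2)cc1` gives > 100000 nM (a limit)
Compound 3 `COc1ccc(CNc2ncnc3c2ncn3C2CCCCO2)c(OC)c1` gives > 25000 nM (a limit)

Going by these compounds, compound 2 has only a limit (> 100000 nM) and no number, so its exact place stays open (the limit of > 100000 nM in this assay, at which 1 of the 3 values shown sits). Compound 4 `COc1ccc(CNc2ncnc3c2ncn3C2CCCCO2)cc1OC` carries methoxy in place of hydrogen on an aromatic carbon, ortho to a methoxy group (methoxy in place of hydrogen on an aromatic carbon). The same kind of change was measured once (a step that the two limits leave unreadable from compound 2 to compound 3), and the other measured step (an at least 1.2-fold higher number from compound 1 to compound 2 (0.09 log units; that floor lies within the scatter)) is a different change. Neither shows a step beyond the scatter, so none is expected in this assay here, and another limit is likely. The estimated step reads (a number no higher from compound 2 to compound 4 (the limit leaves the size open)). Compound 4 is estimated at 100000 nM (expected range 30000 nM to 300000 nM).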

Compound 4, half-maximal inhibitory concentration: > 100000 nM
Compound 4: a limit, no number; the forecaster's own chance of this, stated with the estimate: 60%; the middle value sits exactly at the limit.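

No step can be read between compound 2 and compound 4 in this assay, since both values are limits and not numbers: the limit of > 100000 nM in this assay, at which 2 of the 4 values shown sit.

Going by these compounds, whether methoxy in place of hydrogen on an aromatic carbon shifts the number at all stays open, in compound 3 as in compound 4.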